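Halogen swap on the strongest sulfonamide of the series

The compounds below may be only part of what the source reports. "The series", "measured", "known", "first", "only" and "open" are said of these compounds alone.

Three measured compounds share one core. Compound 1 `Cc1ccn2nc(S(=O)(=O)Nc3c(Cl)ccc4cccnc34)nc2n1` gives 37.2 nM in an assay for inhibition of acetolactate synthase (Nicotiana tabacum); on this read-out higher numbers stand for weaker inhibition and lower numbers for stronger inhibition. Compound 2 `Cc1cc(C)n2nc(S(=O)(=O)Nc3c(Cl)ccc4cccnc34)nc2n1` gives 9.4 nM, and compound 3 `Cc1ccn2nc(S(=O)(=O)Nc3c(Br)ccc4cccnc34)nc2n1` gives 19.2 nM. Compound 2 stands lowest of the three: a 4.0-fold lower number from compound 1 to compound 2 (0.60 log units; beyond the scatter), methyl in place of hydrogen on an aromatic carbon, and its gap to compound 3 is also beyond the scatter, so it is the most potent measured compound. The change to compound 4 `Cc1cc(C)n2nc(S(=O)(=O)Nc3c(F)ccc4cccnc34)nc2n1` is fluoro in place of chloro on an aromatic carbon. Within the data shown here, the only measured halogen swap, a 1.9-fold lower number from compound 1 to compound 3 (0.29 log units; within the scatter), bromo in place of chloro on an aromatic carbon, stayed within the scatter. A similarly small step is therefore expected in this assay, if anything toward a somewhat higher number, giving an expected 1.6-fold higher number from compound 2 to compound 4 (0.20 log units; within the scatter). Compound 4 is estimated at 15 nM, within 6 nM to 40 nM.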

Compound 4, half-maximal inhibitory concentration: 7.7 nM
Estimate against measurement, compound 4: 1.9-fold (0.29 log units) above; measured number inside the range.
By their numbers in this assay, from the lowest: compounds 4 and 2 (each within the scatter of the next); then compounds 3 and 1 (each within the scatter of the next).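

Fluoro in place of chloro on this aromatic carbon, ortho to a large group, gives a 1.2-fold lower number from compound 2 to compound 4 (0.09 log units; within the scatter) in this assay on the core carrying the added methyl. Chloro can therefore give way to fluoro as well as to bromo with both steps staying within the scatter, and a 1.9-fold lower number from compound 1 to compound 3 (0.29 log units; within the scatter) shows the bromo step on the core without that methyl. Nothing shown explains why these halogen swaps remain so small.
On these data alone, whether this tolerance extends beyond halogens stays open, for example to an amine or a methoxy group on this carbon. Bromo on the core with the added methyl also stays open.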